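Sulfonyl substituent exchange on an aryl carbamate core

The source may hold more compounds than are shown below. What is called first, only, known or untested is meant among the compounds shown, and "the series" means these compounds.

Compound 1 `CC(C)c1cccc(C(C)C)c1OC(=O)NS(=O)(=O)N1CCOCC1` — > 100000 nM
Compound 2 `CC(C)c1cccc(C(C)C)c1OC(=O)NS(=O)(=O)N1CCc2ccccc21` — 43000 nM

The two measured compounds share a core and differ only in the group on the sulfonyl sulfur. In an assay on liver for inhibition of sterol O-acyltransferase 1 (Rattus norvegicus), using microsomes (on this read-out higher numbers stand for weaker inhibition and lower numbers for stronger inhibition), compound 1 gives > 100000 nM, which is a limit of the assay rather than a number. Within the data shown here, compound 2 gives 43000 nM in this assay and is therefore the only compound for which an actual number exists. The step of an at least 2.3-fold lower number from compound 1 to compound 2 (0.36 log units; beyond the scatter) runs from a limit, so only its lower bound is known (the limit of > 100000 nM in this assay, at which 1 of the 2 values shown sits).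

Compound 3 `CC(C)c1cccc(C(C)C)c1OC(=O)NS(=O)(=O)Oc1ccccc1` takes the same place on the sulfonyl sulfur once more: phenoxy in place of 2,3-dihydro-1H-indol-1-yl on a sulfonyl sulfur. Among the measured compounds shown here, only one measured step bears on this position, the one from compound 1 to compound 2, and it was at least modest in size. Whether a phenoxy group behaves like the dihydroindolyl group of compound 2 or like the morpholinyl group of compound 1 cannot be read from the two numbers. The step of a 1.2-fold higher number from compound 2 to compound 3 (0.07 log units; within the scatter) is therefore expected to stay close to the scatter. Compound 3 is estimated at 50000 nM in this assay, with a range from 15000 nM to 150000 nM.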

Compound 3, half-maximal inhibitory concentration: > 50000 nM
Compound 3 gave a limit, no number; the forecaster's own chance of this, stated with the estimate: 30%; the middle value lies on the limit itself.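

In this assay compound 3 gives a limit of the assay and not a number, so phenoxy on the sulfonyl sulfur adds a second limit at this position: the limit of > 50000 nM in this assay, at which 1 of the 3 values shown sits.

The step of an at least 1.1-fold higher number from compound 2 to compound 3 (0.06 log units; that floor lies within the scatter) is known only by its floor, and since that floor lies within the scatter, the change from 2,3-dihydro-1H-indol-1-yl to phenoxy shows no readable difference, though a larger one is not excluded. The step between compound 1 and compound 3 cannot be read, as both of its ends are limits. Among these compounds, compound 2 remains the only compound with an actual number, 43000 nM.

On these data alone, whether the true value of compound 3 lies close to that of compound 2 or far from it stays open, and so does the question of whether phenoxy is closer in this assay to 2,3-dihydro-1H-indol-1-yl or to morpholin-4-yl. Also open, as far as these compounds go, is how an anilino group, with a nitrogen where phenoxy has its oxygen, or a piperidin-1-yl group would fare on the same sulfonyl sulfur.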